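Lengthening the chain on the shared core one carbon further

The source may hold more compounds than are shown below. What is called first, only, known or untested is meant among the compounds shown, and "the series" means these compounds.

Three compounds share one core and differ only in the chain on one aromatic carbon. Compound 1 `CCc1ccc(NC(=O)N[C@H](C)c2ccccc2)cc1` carries an ethyl, compound 2 `CC(C)c1ccc(NC(=O)N[C@H](C)c2ccccc2)cc1` an isopropyl, and compound 3 `CCCCc1ccc(NC(=O)N[C@H](C)c2ccccc2)cc1` a butyl. In an ADME assay on the whole organism with Oryza sativa as the target, tested at 0.1 uM (on this read-out lower numbers stand for a stronger effect and higher numbers for a weaker effect at the one concentration tested), compound 1 gives 95%, compound 2 gives 99%, and compound 3 gives 100%. Compound 3 stands with the highest of the three numbers, yet its neighbours lie close: a number 1 percentage points higher from compound 2 to compound 3 (within the scatter) and a number 5 percentage points higher from compound 1 to compound 3 (within the scatter), both within the scatter, so the three are not told apart.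

Compound 4 `CCCCCc1ccc(NC(=O)N[C@H](C)c2ccccc2)cc1` takes the chain one carbon further. Compared with compound 3, the change is methyl in place of hydrogen on a saturated chain carbon, four bonds along the chain from an aromatic carbon.

The earlier steps shown here all lengthened or branched this same chain: a number 4 percentage points higher from compound 1 to compound 2 (within the scatter), a number 5 percentage points higher from compound 1 to compound 3 (within the scatter) and a number 1 percentage points higher from compound 2 to compound 3 (within the scatter), none beyond the scatter. Among the compounds with values here, those steps are the only guide, and they suggest that adding one more methyl on the chain will not move this assay beyond the scatter either.

Compound 4 is therefore expected to give about 99%, within a range from 92% to 104%. The step this estimate means, a number 1 percentage points lower from compound 3 to compound 4 (within the scatter), is expected to stay inside the usual scatter.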

Compound 4, a percentage reported as activity, at one concentration (the size of the read-out at that concentration, not a potency): 100%
Beside the measured number, compound 4's estimate is 1 percentage points below it; measured number inside the range.
By their numbers in this assay, from the lowest: compounds 1, 2, 3 and 4 (each within the scatter of the next).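

In this assay, the pentyl chain of compound 4 cannot be told apart from the ethyl, isopropyl or butyl chains on the shared core: no change at the digits printed from compound 3 to compound 4 (within the scatter), a number 1 percentage points higher from compound 2 to compound 4 (within the scatter) and a number 5 percentage points higher from compound 1 to compound 4 (within the scatter). The series now reaches one carbon further, and a methyl in place of hydrogen four bonds along the chain from an aromatic carbon produces no step beyond the scatter, so all four chains on this aromatic carbon read alike. Methyl in place of hydrogen has now also been seen on two cores, and the two steps do not differ beyond what repeated measurements would allow: the same change on two cores in this assay, a number 4 percentage points higher (within the scatter) from compound 1 to compound 2 and no change at the digits printed (within the scatter) from compound 3 to compound 4, 4 percentage points apart, within the scatter of two such steps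

All four compounds carry plain saturated carbon chains, so they do not show whether a longer chain such as hexyl would also read the same, or whether a chain ending in an amine or a carboxylic acid would give a clearly different number. They also leave open whether a ring such as phenyl on this aromatic carbon would move the read-out beyond the scatter.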